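A few compounds are considered here, and "the series" means these few. Any claim that something is new, unique, unknown or untested is made for them only; others in the source may bear on it.

For the measured compounds named here, in a functional assay on HCT-15 cells (Homo sapiens) for cytotoxicity, read by trypan blue exclusion, with a stated time of 96 h (a lower number here means a stronger inhibitor of growth, a higher number a weaker inhibitor of growth), compound 1 `COc1ccc(NS(=O)(=O)/C=C/c2c(OC)cc(OC)cc2OC)cc1` gives 100 nM and compound 2 `COc1cc(OC)c(/C=C/S(=O)(=O)Nc2ccc(OC)c(N)c2)c(OC)c1` gives 8 nM, so compound 2 holds the lower of the only two numbers available. Compound 3 `COc1cc(OC)c(/C=C/S(=O)(=O)Nc2ccc(OC)c(NC(C)(C)C(=O)O)c2)c(OC)c1` has not yet been measured. It differs from compound 2 at a single place: 1-carboxy-1-methylethyl in place of hydrogen on a nitrogen on an aromatic ring. In other words, 1-carboxy-1-methylethyl stands in place of hydrogen on a nitrogen on an aromatic ring, which turns amino into (1-carboxy-1-methylethyl)amino.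

Going by the values given here, no measured step shows this exact change, so the guidance is indirect. Among the compounds with values here, the one step available, a 13-fold lower number from compound 1 to compound 2 (1.10 log units; beyond the scatter), is large and came with amino in place of hydrogen on an aromatic carbon. Within the data shown here, that same amino group is the one altered in compound 3. Part of the large drop could therefore be lost, though the data cannot show how much, and a number as low as that of compound 2 remains possible. In this assay, the expected change is a 3.8-fold higher number from compound 2 to compound 3 (0.57 log units; beyond the scatter). For compound 3, the estimated value is 30 nM, with an expected range from 6 nM to 200 nM.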

Compound 3, concentration for 50% growth inhibition: 200 nM
The estimate for compound 3 lay 6.7-fold (0.82 log units) below the measured number; measured number inside the range.
By their numbers in this assay, from the lowest: compound 2; then compounds 1 and 3 (each within the scatter of the next).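

In this assay, 1-carboxy-1-methylethyl in place of hydrogen on the nitrogen gives a 25-fold higher number from compound 2 to compound 3 (1.40 log units; beyond the scatter), so the amino group of compound 2 cannot take this substituent without a large loss. Amino itself had given a 13-fold lower number from compound 1 to compound 2 (1.10 log units; beyond the scatter), whereas (1-carboxy-1-methylethyl)amino gives a 2.0-fold higher number from compound 1 to compound 3 (0.30 log units; within the scatter), which places compound 3 within the scatter of compound 1, so the advantage that came with amino does not appear with this larger group. Nothing available explains why this substitution on the nitrogen has such an effect.

The three compounds leave open whether the loss belongs to the carboxylic acid or to the carbon part of the substituent, a question that a methyl ester of the same group or a plain isopropyl on the nitrogen could help separate. They also leave open whether any group on this nitrogen can keep a number close to that of compound 2, for example a single methyl, an acetyl or the unbranched carboxymethyl.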